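From a Dihalophenyl Arm to a Nitrophenyl Arm

A few compounds are considered here, and "the series" means these few. Any claim that something is new, unique, unknown or untested is made for them only; others in the source may bear on it.

In an assay for inhibition of protein disulfide-isomerase (Homo sapiens), with a stated time of 1 h (a higher number here means a weaker inhibitor, a lower number a stronger inhibitor), compound 1 `Oc1c(C(Nc2ccccn2)c2c(Cl)cccc2Cl)ccc2cccnc12` gives 1890 nM, and compound 3 `CC(=O)c1cc2ccc(C(c3ccc(F)cc3)N3CCCCC3)c(O)c2o1`, built on a different core, gives 1230 nM. Compound 2 `Cc1ccnc(NC(c2ccc3cccnc3c2O)c2c(F)cccc2Cl)c1` reaches only a limit of this assay, > 40000 nM, so its potency is not pinned to a number. That single value accounts for (the limit of > 40000 nM in this assay, at which 1 of the 3 values shown sits). Compound 4 `Cc1ccnc(NC(c2ccc([N+](=O)[O-])cc2)c2ccc3cccnc3c2O)c1` differs from compound 2 in one place: 4-nitrophenyl in place of 2-chloro-6-fluorophenyl on a saturated chain carbon bound to an aromatic carbon and a nitrogen on an aromatic ring. For the measured compounds named here, no measured pair shows this exact exchange, so the size of the step is open, and with compound 2 known only as a limit the step could be none at all or a clear gain in potency. The expected result for compound 4 is 15000 nM, within 2500 nM to 60000 nM. The step expected here is an at least 2.6-fold lower number from compound 2 to compound 4 (0.42 log units; beyond the scatter).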

Compound 4, half-maximal inhibitory concentration: 530 nM
Estimate against measurement, compound 4: 28-fold (1.45 log units) above; measured number outside the range, below it.
By their numbers in this assay, from the lowest: compound 4; then compounds 3 and 1 (each within the scatter of the next). At a limit, above all of these: compound 2.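

Exchanging 2-chloro-6-fluorophenyl for 4-nitrophenyl on the saturated chain carbon gives an at least 75-fold lower number from compound 2 to compound 4 (1.87 log units; beyond the scatter). This is the first step shown at this position, and it shows that the group held there can, with the rest of the molecule unchanged, decide whether the result is a measured number or a limit. Compound 2 stands at a limit, and the full size of the step stays unknown: the limit of > 40000 nM in this assay, at which 1 of the 4 values shown sits.

The compounds shown leave open whether the gain goes with the nitro group itself or with the loss of the chlorine and fluorine. They also leave open how a plain phenyl or an aminophenyl would read on this carbon.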